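Chalcone ketone aryl swap: phenyl to dimethoxyphenyl

A few compounds are considered here, and "the series" means these few. Any claim that something is new, unique, unknown or untested is made for them only; others in the source may bear on it.

Compound 3 `O=C(/C=C/c1cn(-c2ccccc2)nc1-c1ccncc1)c1ccccc1` gives 3100 nM in a functional assay on HCT-116 cells (Homo sapiens) for inhibition, read by sulforhodamine B assay, with a stated time of 72 h (a lower number here means a stronger inhibitor, a higher number a weaker inhibitor), the highest of the three numbers in hand. Compound 2 `O=C(/C=C/c1cn(-c2ccccc2)nc1-c1ccncc1)c1ccsc1` gives 1100 nM and compound 1 `COc1ccc(OC)c(C(=O)/C=C/c2cn(-c3ccccc3)nc2-c2cccnc2)c1` gives 1000 nM. For the measured compounds named here, the one single-site step measured so far is a 2.8-fold higher number from compound 2 to compound 3 (0.45 log units; beyond the scatter), so a change of the aryl on the carbonyl carbon has already moved this assay by a modest amount. Compound 4 `COc1ccc(OC)c(C(=O)/C=C/c2cn(-c3ccccc3)nc2-c2ccncc2)c1` differs from compound 3 by 2,5-dimethoxyphenyl in place of phenyl on a carbonyl carbon. Going by the values given here, compound 1 carries the same 2,5-dimethoxyphenyl on the carbonyl carbon but also a different pyridyl, so no measured step covers this change alone. Given that compound 1 gives 1000 nM, the expected step is a 2.6-fold lower number from compound 3 to compound 4 (0.41 log units; beyond the scatter), toward a lower number. Compound 4 is estimated at 1200 nM, range 500 nM to 3000 nM.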

Compound 4, half-maximal inhibitory concentration: 900 nM
The estimate for compound 4 lay 1.3-fold (0.12 log units) above the measured number; the range from low to high includes it.
By their numbers in this assay, from the lowest: compounds 4, 1 and 2 (each within the scatter of the next); then compound 3.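

In this assay, 2,5-dimethoxyphenyl in place of phenyl on the carbonyl carbon gives a 3.4-fold lower number from compound 3 to compound 4 (0.54 log units; beyond the scatter), so a second replacement of phenyl at this place reaches beyond the scatter. Thiophen-3-yl and 2,5-dimethoxyphenyl are not separated, with a 1.2-fold lower number from compound 2 to compound 4 (0.09 log units; within the scatter), and the pyridyl change is equally unresolved, with a 1.1-fold lower number from compound 1 to compound 4 (0.05 log units; within the scatter), so phenyl alone stands apart among the groups at this place. Nothing measured on these compounds accounts for this.

Open, as far as these compounds go, is whether a single methoxy group on the phenyl would give the same step. Also open, from the compounds shown here alone, is how a carboxylic acid on that ring would read.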